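The source may report more compounds than this note shows. Statements on the series, on what has been measured and on what is new or still open speak of the compounds shown alone.

In an ADME assay on CRFK cells (Felis catus) for cytotoxicity (on this read-out higher numbers stand for lower toxicity in this test and lower numbers for higher toxicity in this test), compound 1 (`CCN(CC)CN1C(=O)/C(=N/NC(=S)Nc2ccccc2)c2cc(Cl)ccc21`) gives 6900 nM and compound 2 (`CCN(CC)CN1C(=O)/C(=N/NC(=S)Nc2ccc(OC)cc2)c2ccccc21`) gives 3500 nM. These two numbers lie within the usual scatter of each other, so compound 2 stands level with compound 1 on the evidence so far. Compound 3 (`CCN(CC)CN1C(=O)/C(=N/NC(=S)Nc2ccccc2)c2ccccc21`) differs from compound 2 in one place: it has hydrogen in place of methoxy on an aromatic carbon, para to a large group, so that 4-methoxyphenyl becomes phenyl (hydrogen in place of methoxy on an aromatic carbon). Going by the values given here, no two measured compounds differ in only one place, so this assay offers no direct precedent for this change. Among the compounds with values here, the only guide is that compound 1 at 6900 nM and compound 2 at 3500 nM sit within the scatter. The expected change, a 1.4-fold higher number from compound 2 to compound 3 (0.15 log units; within the scatter), is therefore not expected to go beyond the scatter, with only a tentative lean towards a higher number. For compound 3 the estimated value is 5000 nM, with an expected range from 2000 nM to 12000 nM.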

Compound 3, half-maximal cytotoxic concentration: 32300 nM
Compound 3: the middle estimate sits 6.5-fold (0.81 log units) below what was measured; the whole stated range lies below it.
By their numbers in this assay, from the lowest: compounds 2 and 1 (each within the scatter of the next); then compound 3.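

In this assay the change from 4-methoxyphenyl to phenyl gives a 9.2-fold higher number from compound 2 to compound 3 (0.97 log units; beyond the scatter) and so shows that this place on the ring is not indifferent to what it carries, although compound 1 and compound 2 had looked level. Replacing the chloro on the core with hydrogen gives a 4.7-fold higher number from compound 1 to compound 3 (0.67 log units; beyond the scatter) in the same direction, so both single changes ending at compound 3 lead to lower toxicity in this test. Nothing measured here accounts for either step.

From the compounds shown here alone, whether any group at this place lowers the number or methoxy alone does remains open, and a fluoro, a methyl or a hydroxyl in its position would begin to separate those readings. Also open, going by these compounds, is whether the diethylamino group, which all three compounds share, could give way to a morpholine without changing the picture.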